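Amino for methyl on the piperidine acyl group of compound 3

The compounds below may be only part of what the source reports. "The series", "measured", "known", "first", "only" and "open" are said of these compounds alone.

Working notes on the naphthalenesulfonamide series. Compound 3 `CCC(=O)N1CCC(NS(=O)(=O)c2ccc(NC(=O)c3ccccc3C)c3ccccc23)CC1` gives 2.5 nM in an assay on L1.2 cells for binding affinity to C-C chemokine receptor type 8 (Homo sapiens); on this read-out higher numbers stand for weaker inhibition and lower numbers for stronger inhibition. Compound 1 `O=C(Nc1ccc(S(=O)(=O)NC2CCCCC2)c2ccccc12)c1ccccc1` gives 4.4 nM, which lies within the scatter of the number for compound 3. Going by the values given here, compound 2 `CCOC(=O)N1CCC(NS(=O)(=O)c2ccc(NCc3ccccc3)c3ccccc23)CC1` gives 45.6 nM, a number far beyond the scatter from that of compound 3; no single-point step links it to compound 3, so only the two numbers can be compared. Compound 4 `Cc1ccccc1C(=O)Nc1ccc(S(=O)(=O)NC2CCN(C(=O)CN)CC2)c2ccccc12` differs from compound 3 by amino in place of methyl on a saturated chain carbon bound to a carbonyl carbon. Among the compounds with values here, no measured pair in the set shows such a change, so no measured step guides the expectation. The change is expected to be small in this assay, at most a slight weakening, as a 1.6-fold higher number from compound 3 to compound 4 (0.20 log units; within the scatter). For compound 4 the estimate is 4 nM, with a range from 1.5 nM to 12 nM.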

Compound 4, inhibition constant: 4.1 nM
Estimate against measurement, compound 4: 1.0-fold (0.01 log units) below; the range from low to high includes it.
By their numbers in this assay, from the lowest: compounds 3, 4 and 1 (each within the scatter of the next); then compound 2.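

Amino in place of methyl on a saturated chain carbon bound to a carbonyl carbon gives a 1.6-fold higher number from compound 3 to compound 4 (0.21 log units; within the scatter) in this assay and this is the only single-place step in the series. The earlier compounds shown here showed nothing about this place; here, carbon gives way to nitrogen and a hydrogen-bond donor and acceptor enter, with the number staying within the scatter. No measurement at hand explains this result.

Still open, going by these compounds, is whether a carboxylic acid, a dimethylamino group or a longer chain ending in an amine would also stay within the scatter at this place.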